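Methoxy to Hydroxy: What to Expect for Compound 4

This account rests on a few compounds, and the source may have more. Where it says the series, first, only, none or still open, it means among the compounds named here.

Of the compounds shown here, three built on one shared core have been tested in a functional assay on PC-3 cells (Homo sapiens) for inhibition, read by sulforhodamine B assay, with a stated time of 48 h; a lower number here means a stronger inhibitor, a higher number a weaker inhibitor. Compound 1 `O=C(Nc1cccc(-n2cc(-c3ccncc3)c(-c3ccc(Cl)c(O)c3)n2)c1)Nc1cccc(C(F)(F)F)c1` gives 950 nM. Compound 2 `COc1cc(-c2nn(-c3cccc(NC(=O)c4cccc(C(F)(F)F)c4)c3)cc2-c2ccncc2)ccc1Cl` gives 1230 nM. For the measured compounds named here, compound 3 `COc1cc(-c2nn(-c3cccc(NC(=O)Nc4ccc(Cl)c(Cl)c4)c3)cc2-c2ccncc2)ccc1Cl` gives 550 nM, the lowest of the three numbers, although its gap to compound 1 lies within the scatter, so those two cannot be ranked; only the step of a 2.2-fold lower number from compound 2 to compound 3 (0.35 log units; beyond the scatter) lies beyond the scatter.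

Compound 4 `O=C(Nc1cccc(-n2cc(-c3ccncc3)c(-c3ccc(Cl)c(O)c3)n2)c1)Nc1ccc(Cl)c(Cl)c1` arises from compound 3 by a single change: hydrogen in place of methyl on an oxygen on an aromatic ring. Going by the values given here, no measured step covers this change by itself. Compound 1 carries the hydroxy and compound 3 the methoxy, but they also differ in the group on the carbonyl carbon, so their two values, which sit within the scatter of each other, give no clean reading of the swap. With nothing that bears on it directly, the step expected in this assay, no change at the digits printed from compound 3 to compound 4 (within the scatter), is none beyond the scatter. Compound 4 is therefore estimated to give 550 nM, with a range from 220 nM to 1400 nM.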

Compound 4, half-maximal inhibitory concentration: 830 nM
The estimate for compound 4 lay 1.5-fold (0.18 log units) below the measured number; low and high end bracket the measured number.
By their numbers in this assay, from the lowest: compounds 3, 4, 1 and 2 (each within the scatter of the next, the first and the last beyond it).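

In this assay, the swap of methoxy for hydroxy on the aromatic ring can now be read by itself, with nothing else changing (a 1.5-fold higher number from compound 3 to compound 4 (0.18 log units; within the scatter)), and this pair shows no difference that stands clear of the usual scatter. With the hydroxy held in place, the group on the amide-type nitrogen can be read as well (a 1.1-fold lower number from compound 1 to compound 4 (0.06 log units; within the scatter)), so 3,4-dichlorophenyl and 3-(trifluoromethyl)phenyl cannot be told apart in this pair. Nothing at hand explains either result.

The compounds shown carry only hydrogen or methyl on this oxygen, so a longer chain there, such as ethyl or propyl, remains open. So does replacing the oxygen group with an amine.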